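From an Amide to a Plain Piperidine on the Shared Core

The source may report more compounds than this note shows. Statements on the series, on what has been measured and on what is new or still open speak of the compounds shown alone.

Compound 3 `CCCC(=O)NC1CCN(S(=O)(=O)c2c(C)cc(C)cc2C)CC1` carries a (propylcarbonyl)amino group on a saturated ring carbon of the shared core. In a functional assay on DLD-1 cells (Homo sapiens) for antiproliferative activity, read by CellTiter-Glo, with a stated time of 72 h (on this read-out lower numbers stand for stronger inhibition and higher numbers for weaker inhibition), compound 3 gives only a limit, > 5000 nM. Compound 1 `Cc1cc(C)c(S(=O)(=O)N2CCC(c3ccccc3)CC2)c(C)c1`, with a phenyl on that saturated ring carbon, likewise reaches only the limit > 5000 nM. For the measured compounds named here, the single measured step, a step that the two limits leave unreadable from compound 1 to compound 3, is thus unreadable, both ends sitting at the limit of > 5000 nM in this assay, at which 2 of the 3 values shown sit. Compound 4 `Cc1cc(C)c(S(=O)(=O)N2CCC(N3CCCCC3)CC2)c(C)c1` differs from compound 3 by piperidin-1-yl in place of (propylcarbonyl)amino on a saturated ring carbon. Compound 2 `Cc1cc(C)c(S(=O)(=O)N2CCC(N3CCC(Cc4ccc(F)cc4)CC3)CC2)c(C)c1`, whose piperidin-1-yl additionally carries a fluorobenzyl group, gives 18 nM in this assay. The value of compound 2, 18 nM, is the only pointer, so the step of an at least 3.3-fold lower number from compound 3 to compound 4 (0.52 log units; beyond the scatter) is expected to run toward stronger inhibition. Compound 4 is estimated at 1500 nM, within 200 nM to 5000 nM.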

Compound 4, half-maximal inhibitory concentration: 2200 nM
Compound 4: middle estimate off by 1.5-fold (0.17 log units), on the low side; the range from low to high includes it.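

Piperidin-1-yl on this saturated ring carbon brings the shared core into the readable range without any further group, giving an at least 2.2-fold lower number from compound 3 to compound 4 (0.35 log units; beyond the scatter) and an at least 2.2-fold lower number from compound 1 to compound 4 (0.35 log units; beyond the scatter). Both steps start from a limit, so their true size stays unknown: the limit of > 5000 nM in this assay, at which 2 of the 4 values shown sit.

Hydrogen in place of 4-fluorobenzyl gives a 120-fold higher number from compound 2 to compound 4 (2.09 log units; beyond the scatter), so most of the strength goes with that added group rather than with the piperidin-1-yl alone. Going by these compounds, whether a plain benzyl would serve as well as 4-fluorobenzyl, or an open-chain amine such as dimethylamino as well as piperidin-1-yl, stays open.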